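This account rests on a few compounds, and the source may have more. Where it says the series, first, only, none or still open, it means among the compounds named here.

For the measured compounds named here, compound 3 `O=C(/C=C/c1ccc(O)cc1)c1c(O)cccc1OCCC1CCCC1` is the only one of the three compounds to give a number in a functional assay on MDA-MB-231 cells (Homo sapiens) for antiproliferative activity, read by sulforhodamine B assay; on this read-out lower numbers stand for stronger inhibition of growth and higher numbers for weaker inhibition of growth: compound 3 gives 3340 nM. Compound 1 `O=C(/C=C/c1ccc(O)cc1)c1c(O)cccc1OCC1CCCCC1` reaches only a limit of this assay, > 30000 nM. Compound 2 `CC(C)=CCOc1cccc(O)c1C(=O)/C=C/c1ccc(O)cc1` likewise reaches only a limit, > 30000 nM. The steps of an at least 8.9-fold lower number from compound 1 to compound 3 (0.95 log units; beyond the scatter) and an at least 8.9-fold lower number from compound 2 to compound 3 (0.95 log units; beyond the scatter) were each at least modest, whereas the step that the two limits leave unreadable from compound 1 to compound 2 cannot be read, both of its values sitting at the limit (the limit of > 30000 nM in this assay, at which 2 of the 3 values shown sit). Compound 4 `O=C(/C=C/c1ccc(O)cc1)c1c(O)cccc1OCc1ccccc1` differs from compound 3 by phenyl in place of cyclopentylmethyl on a saturated chain carbon bound to an oxygen on an aromatic ring. Going by the values given here, none of the measured steps exchanges the cyclopentylmethyl for an aromatic ring, so the step of a 1.5-fold higher number from compound 3 to compound 4 (0.18 log units; within the scatter) is expected to stay small, leaning if anything toward a higher number. Compound 4 is therefore estimated at 5000 nM, with a range from 1500 nM to 20000 nM.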

Compound 4, concentration for 50% growth inhibition: > 30000 nM
Compound 4: a limit, no number (the forecaster's own chance of this, stated with the estimate: 15%); middle value at least 6.0-fold (0.77 log units) away from the limit.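

In this assay, phenyl in place of cyclopentylmethyl at this place gives an at least 8.9-fold higher number from compound 3 to compound 4 (0.95 log units; beyond the scatter), so an aromatic ring here does not keep the growth inhibition seen with compound 3. Compound 4 gives only a limit and no number, which leaves cyclopentylmethyl as the only group shown here to give a number. The steps from compound 1 and from compound 2 to compound 4 cannot be read: the limit of > 30000 nM in this assay, at which 3 of the 4 values shown sit.

As far as these compounds go, how far compound 4 lies beyond its limit stays open. So does whether a longer chain ending in cyclopentyl, or an amine at this place, would give a lower number than compound 3.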